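The source may hold more compounds than are shown below. What is called first, only, known or untested is meant among the compounds shown, and "the series" means these compounds.

Compound 1 `CC(C)Oc1cc(Oc2ccc(S(C)(=O)=O)cc2)cc(-c2cccc(=O)[nH]2)c1` gives 11000 nM in a physicochemical assay for solubility, in phosphate buffer, measured as kinetic solubility, with a stated time of 24 h, at pH 6.5 (a lower number here means a less soluble compound, a higher number a more soluble compound), the lowest of the three numbers in hand, with compound 3 within the scatter of it and compound 2 well beyond. Compound 2 `CC(C)Oc1cc(Oc2ccc(S(C)(=O)=O)cc2)cc(-c2cncc(=O)[nH]2)c1` gives 118000 nM in this assay, and compound 3 `Cc1cc(=O)[nH]c(-c2cc(Oc3ccc(S(C)(=O)=O)cc3)cc(OC(C)C)c2)n1` gives 15000 nM; the two steps from compound 1 are an 11-fold higher number from compound 1 to compound 2 (1.03 log units; beyond the scatter) and a 1.4-fold higher number from compound 1 to compound 3 (0.13 log units; within the scatter). Compound 4 `COc1cnc(-c2cc(Oc3ccc(S(C)(=O)=O)cc3)cc(OC(C)C)c2)[nH]c1=O` differs from compound 1 in one place: a group of 9 heavy atoms (5 carbon, 2 nitrogen, 2 oxygen; one six-membered aromatic ring with 2 hetero atoms) in place of a group of 7 heavy atoms (5 carbon, 1 nitrogen, 1 oxygen; one six-membered aromatic ring with 1 hetero atom), on an aromatic carbon. Both measured steps bear on this change, since each likewise puts a six-membered aromatic ring with 2 hetero atoms in place of the ring with 1 hetero atom; one was large, the other lay within the scatter. A modest rise is therefore expected, a 2.7-fold higher number from compound 1 to compound 4 (0.44 log units; beyond the scatter). Compound 4 is estimated at 30000 nM, with a range from 10000 nM to 110000 nM.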

Compound 4, solubility: 7100 nM
Estimate against measurement, compound 4: 4.2-fold (0.63 log units) above; measured number below the stated range.
By their numbers in this assay, from the lowest: compounds 4, 1 and 3 (each within the scatter of the next, the first and the last beyond it); then compound 2.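

At this position, a ring with 2 hetero atoms does not by itself bring the high number of compound 2: the methoxy-bearing ring gives a 17-fold lower number from compound 2 to compound 4 (1.22 log units; beyond the scatter), while a 1.5-fold lower number from compound 1 to compound 4 (0.19 log units; within the scatter) leaves it level with the ring with 1 hetero atom. The two substituted rings also part slightly, with a 2.1-fold lower number from compound 3 to compound 4 (0.32 log units; beyond the scatter). Nothing measured here explains these steps. The compounds shown leave open whether an amine or a carboxylic acid on this ring would keep the number of compound 2 . They also leave open how an ethoxy group or a longer ether chain would compare with the methoxy group of compound 4 .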